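Boron-containing inhibitors: swapping butyl for iodo

The source may report more compounds than this note shows. Statements on the series, on what has been measured and on what is new or still open speak of the compounds shown alone.

Measured so far in an assay on HEK293 cells for inhibition of transient receptor potential cation channel subfamily V member 6 (Homo sapiens), read by FLIPR, with a stated time of 5 min; a lower number here means a stronger inhibitor, a higher number a weaker inhibitor:
Compound 1, `O=C1O[B-](c2ccccc2)(c2ccccc2)[NH2+][C@H]1CO`: 20200 nM
Compound 2, `OB(c1ccc(C(F)(F)F)cc1)c1ccc(C(F)(F)F)cc1`: 11200 nM
Compound 3, `CCCCc1ccc([B-]2(c3ccccc3)[NH2+]CCO2)cc1`: 12100 nM

All three numbers are high, which means weak inhibition. Compound 3 sits within the usual scatter of both compound 2 and compound 1, so on these three numbers alone none of them can be set apart from the others; they read as one group of weak inhibitors.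

Compound 4, `Ic1ccc([B-]2(c3ccccc3)[NH2+]CCO2)cc1`, has not yet been measured. It differs from compound 3 in one place: iodo in place of butyl on an aromatic carbon. Within the data shown here, nothing among the measured compounds tests a change of this kind, so there is no measured step to lean on. Given that compound 3 gives 12100 nM and the whole set stays in the same weak range, the expectation for compound 4 is a step of a 1.0-fold lower number from compound 3 to compound 4 (0.00 log units; within the scatter) in this assay, in no clear direction and not beyond the scatter. For compound 4 the estimated value is therefore 12000 nM, with a range from 5000 nM to 30000 nM.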

Compound 4, half-maximal inhibitory concentration: 5200 nM
The estimate for compound 4 lay 2.3-fold (0.36 log units) above the measured number; low and high end bracket the measured number.
By their numbers in this assay, from the lowest: compound 4; then compounds 2, 3 and 1 (each within the scatter of the next).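

In this assay, this aromatic carbon turns out to respond to what it carries: iodo in place of butyl gives a 2.3-fold lower number from compound 3 to compound 4 (0.37 log units; beyond the scatter), a modest step but one beyond the scatter. The earlier compounds shown here could not show this, as none of them formed a pair differing in one place. The result also shows that the butyl chain is not needed at this position to keep the inhibition seen with compound 3, although no data here explain why the number falls.

On these data alone, it remains open whether the gain comes from having iodo there or simply from losing butyl. The compounds shown include no bromo, chloro, methyl or bare hydrogen at this carbon to separate those readings, and no amine or carboxylic acid to test a very different kind of group.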